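This account rests on a few compounds, and the source may have more. Where it says the series, first, only, none or still open, it means among the compounds named here.

In a functional assay on MCF7 cells (Homo sapiens) for cytotoxicity, read by MTT assay, with a stated time of 72 h (a lower number here means a stronger inhibitor, a higher number a weaker inhibitor), compound 2 (`CNC(=O)c1cc(Oc2ccc(NC(=O)c3cc(-c4ccc(Cl)cc4)ncn3)cc2)ccn1`) gives > 100000 nM, which is a limit of the assay and not a number. Compound 1 (`CNC(=O)c1cc(Oc2ccc(NC(=O)c3cc(-c4ccc(Br)cc4)ncn3)cc2)ccn1`) gives > 100000 nM, and this too is only a limit. Both compounds therefore stand at the same place, (the limit of > 100000 nM in this assay, at which 2 of the 2 values shown sit), so compound 2 has no measured potency from which to count.

Compound 3 (`CNC(=O)c1cc(Oc2ccc(NC(=O)c3cc(-c4ccccc4)ncn3)cc2)ccn1`) departs from compound 2 by a single change, hydrogen in place of chloro on an aromatic carbon, turning 4-chlorophenyl into phenyl. Within the data shown here, the one measured step that bears on this is a change at the same carbon, chloro in place of bromo, given as a step that the two limits leave unreadable from compound 1 to compound 2. Among the measured compounds shown here, it offers no size to carry over, and the data show no halogen-bearing compound with a readable number. No step beyond the scatter can therefore be expected in this assay, and no direction can be argued, so compound 3 is expected to stay near the same limit. The expected change is a number no higher from compound 2 to compound 3 (the limit leaves the size open). For compound 3 the estimated value is 100000 nM, with an expected range from 30000 nM to 200000 nM.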

Compound 3, half-maximal inhibitory concentration: 18200 nM
Beside the measured number, compound 3's estimate is 5.5-fold (0.74 log units) above it; the measured number lies below the stated range.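

In this assay, the group on this aromatic carbon, para to a large group, proves able to move the read-out: with hydrogen in place of chloro, the series gives its first readable number, an at least 5.4-fold lower number from compound 2 to compound 3 (0.73 log units; beyond the scatter). Hydrogen in place of bromo at the same carbon gives a matching result, an at least 5.4-fold lower number from compound 1 to compound 3 (0.73 log units; beyond the scatter), and in both steps the printed size is only a minimum. The step between the two halogen compounds cannot be read, so chloro and bromo cannot be ranked against each other, and the comparison with compound 3 still rests on a limit of the assay on the halogen side: the limit of > 100000 nM in this assay, at which 2 of the 3 values shown sit.

The compounds shown leave open whether hydrogen is special at this carbon or whether a small group such as fluoro, methyl, methoxy or an amine would also give a readable number. They also leave open how large the true steps are, and whether a carboxylic acid or a longer chain at this carbon would lower the number further or return it to the limit.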